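Methyl on the aromatic ring: from benzoxazolone to piperidine amide

The source may hold more compounds than are shown below. What is called first, only, known or untested is meant among the compounds shown, and "the series" means these compounds.

Two cores stand side by side in this set. Compound 1 `Cc1ccc(CN(C)CCCn2c(=O)oc3ccccc32)cc1` and compound 3 `Cc1ccc(CN(C)CCCn2c(=O)oc3ccccc32)c(C)c1` share one core, while compound 2 `O=C(Nc1ccccc1)C1CCN(Cc2ccccc2)CC1` and compound 4 `Cc1ccc(CN2CCC(C(=O)Nc3ccccc3)CC2)cc1` share the other; the difference between the two cores is not broken down here. In an assay on membranes from liver for displacement of a labelled ligand from Sigma non-opioid intracellular receptor 1 (Rattus norvegicus), read by scintillation counting (on this read-out higher numbers stand for weaker inhibition and lower numbers for stronger inhibition), compound 1 gives 871 nM and compound 3 gives 1830 nM. The change between them, (methyl in place of hydrogen on an aromatic carbon), produced a 2.1-fold higher number from compound 1 to compound 3 (0.32 log units; beyond the scatter). Compound 2 gives 48.1 nM in this assay, the lowest number of the three measured compounds, with all steps to the others beyond the scatter.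

Compound 4 has not been measured. It differs from compound 2 by methyl in place of hydrogen on an aromatic carbon. Within the data shown here, this is the same kind of change as the one from compound 1 to compound 3, but the surroundings differ: there the entering methyl sits ortho to a large group and meta to a methyl group, here it sits para to a large group. Among the measured compounds shown here, with only one measured example of this kind of change, the expectation rests on that single step and is held loosely: the expected step is a 1.6-fold higher number from compound 2 to compound 4 (0.19 log units; within the scatter), a smaller shift than the one seen from compound 1 to compound 3. Compound 4 is therefore estimated at 75 nM in this assay, expected to lie between 25 nM and 250 nM.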

Compound 4, inhibition constant: 105 nM
For compound 4 the middle estimate is 1.4-fold (0.15 log units) below the measured one; low and high end bracket the measured number.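

In this assay, the change of phenyl to 4-methylphenyl produces a 2.2-fold higher number from compound 2 to compound 4 (0.34 log units; beyond the scatter), a modest step that can be set directly beside the step on the other core: the same change on two cores in this assay, a 2.1-fold higher number (0.32 log units; beyond the scatter) from compound 1 to compound 3 and a 2.2-fold higher number (0.34 log units; beyond the scatter) from compound 2 to compound 4, 1.0-fold (0.02 log units) apart, within the scatter of two such steps

In this pair of cores, the methyl in place of hydrogen therefore carries over in the same direction and at much the same size, although it enters different surroundings on each core. Among these compounds, this rests on only two pairs in a single assay, so it does not show why the steps agree or that they would agree on a further core or at another place on the ring.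

The compounds shown leave open whether an ethyl group, a methoxy group or a chlorine atom in place of the entering methyl would move the number equally on both cores. They also leave open whether the match between the two steps would hold on any read-out other than this one.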